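Swapping Propyl for Phenyl on an Active Acid

The source may report more compounds than this note shows. Statements on the series, on what has been measured and on what is new or still open speak of the compounds shown alone.

compound 1 `O=C(O)C(Cc1ccc(Cl)cc1)Oc1ccccc1` (> 25 mg/kg, a limit of the assay)
compound 2 `CC(C)c1ccc(OC(CCCCCc2ccc(Cl)cc2)C(=O)O)cc1` (10 mg/kg)
compound 3 `CCCc1ccc(CC(C)(Oc2ccc(C(C)C)cc2)C(=O)O)cc1` (0.5 mg/kg)

All three compounds were tested in a functional assay on the whole organism for inhibition, with Rattus norvegicus as the target (on this read-out higher numbers stand for an effect only at larger amounts of compound and lower numbers for an effect already at smaller amounts), and share a carboxylic acid group. Compound 1 gave only a limit (> 25 mg/kg) and not a true number. Of the two real numbers, compound 3 (0.5 mg/kg) has the lower one, so it acts at a smaller dose than compound 2 (10 mg/kg), a gap well beyond the usual scatter.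

The next compound to be measured is compound 4 `CC(C)c1ccc(OC(C)(Cc2ccc(-c3ccccc3)cc2)C(=O)O)cc1`. It differs from compound 3 in one place: phenyl in place of propyl on an aromatic carbon, para to a large group phenyl in place of propyl on an aromatic carbon and the rest of the structure is unchanged.

Among the measured compounds shown here, no measured pair of compounds differs by a single change, so there is no direct precedent for this swap. For the measured compounds named here, compound 3 (0.5 mg/kg) sits at the low end of the numbers so far, which leaves more room to rise than to fall. The expected step is a 2.4-fold higher number from compound 3 to compound 4 (0.38 log units; beyond the scatter) toward a higher number, modest in size and not far beyond the scatter. Compound 4 is estimated at 1.2 mg/kg with an expected range from 0.3 mg/kg to 6 mg/kg in the measurement to come.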

Compound 4, dose for half-maximal effect: 1 mg/kg
The estimate for compound 4 lay 1.2-fold (0.08 log units) above the measured number, and the stated range covers the measured number.
By their numbers in this assay, from the lowest: compounds 3 and 4 (each within the scatter of the next); then compound 2. At a limit, above all of these: compound 1.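

Among the compounds shown here, replacing propyl with phenyl on an aromatic carbon, para to a large group, gives the first direct comparison in this assay, with a 2.0-fold higher number from compound 3 to compound 4 (0.30 log units; within the scatter). This position therefore accepts an aromatic ring of carbon as well as propyl, with no difference that this read-out can separate from ordinary repeat scatter. For the compounds shown here, none of the earlier compounds could show this. None of them formed a single-change pair. The two groups differ in size and in having a ring, yet nothing measured here explains why their numbers stay so close, so the result offers no cause for this similarity.

As far as these compounds go, two groups at one position give only a narrow view, so it remains open how far this tolerance extends, for instance to a longer chain such as hexyl or to a second phenyl added beyond the first. From the compounds shown here alone, whether other kinds of group would fit equally well also remains open, as an amine or a hydroxyl on the entering phenyl would test that directly.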